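Extending the Chain from Compound 3 to Compound 4

A few compounds are considered here, and "the series" means these few. Any claim that something is new, unique, unknown or untested is made for them only; others in the source may bear on it.

Compound 1, `CCSC[C@H](NC(C)=O)C(=O)CCl`: in a functional assay on NALM-6 cells (Homo sapiens) (on this read-out lower numbers stand for stronger inhibition and higher numbers for weaker inhibition), compound 1 gives 52800 nM
Compound 2, `CCCSC[C@H](NC(C)=O)C(=O)CCl`: in this assay compound 2 gives 6900 nM
Compound 3, `CCCCCCSC[C@H](NC(C)=O)C(=O)CCl`: in this assay compound 3 gives 3300 nM

Compound 3 holds the lowest number of the three in this assay; compound 2 is nearest to it and compound 1 furthest, and both gaps lie beyond the scatter. Compound 4, `CCCCCCCCSC[C@H](NC(C)=O)C(=O)CCl`, has not yet been measured. It differs from compound 3 by ethyl in place of hydrogen on a saturated chain carbon, six bonds along the chain from a sulfur. The measured steps that bear on this are all chain lengthenings at the same end: a 7.7-fold lower number from compound 1 to compound 2 (0.88 log units; beyond the scatter), a 16-fold lower number from compound 1 to compound 3 (1.20 log units; beyond the scatter), and a 2.1-fold lower number from compound 2 to compound 3 (0.32 log units; beyond the scatter). Each lengthening lowered the number, but the later step was smaller than the earlier ones, so a further extension is expected to bring only a modest step lower, if one beyond the scatter at all. For compound 4 the expected step is a 1.5-fold lower number from compound 3 to compound 4 (0.18 log units; within the scatter). Compound 4 is therefore estimated at 2200 nM, with a range from 800 nM to 5000 nM.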

Compound 4, half-maximal inhibitory concentration: 5600 nM
The estimate for compound 4 lay 2.5-fold (0.41 log units) below the measured number, and the stated range ends below it.
By their numbers in this assay, from the lowest: compounds 3, 4 and 2 (each within the scatter of the next, the first and the last beyond it); then compound 1.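

In this assay, ethyl at this place, six bonds along the chain from a sulfur, gives a 1.7-fold higher number from compound 3 to compound 4 (0.23 log units; within the scatter), so the lowering seen with the earlier lengthenings does not carry on to this chain. The same holds against the shorter compound, with a 1.2-fold lower number from compound 2 to compound 4 (0.09 log units; within the scatter), although compound 3 remains the one exception, since its own step from compound 2 lies just beyond the scatter; what survives of the chain effect is a 9.4-fold lower number from compound 1 to compound 4 (0.97 log units; beyond the scatter), which places the clear separation at the short end of the series. Nothing available explains why the steps flatten out.

The compounds shown leave open whether a still longer chain would stay level with compound 4 or move away from it. They also leave open what an amine or a carboxylic acid at the chain end would do at this position.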